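From hydroxy to methoxy on compound 1

The source may hold more compounds than are shown below. What is called first, only, known or untested is meant among the compounds shown, and "the series" means these compounds.

In a functional assay on SF-539 cells (Homo sapiens) for antiproliferative activity, read by sulforhodamine B assay, with a stated time of 48 h (a lower number here means a stronger inhibitor, a higher number a weaker inhibitor), compound 1 `O=C(NCCCNc1cc(-c2cn(-c3ccccc3)nc2-c2cccc(O)c2)ccn1)Nc1ccc(F)cc1` gives 1980 nM, and compound 2 `O=C(NCCCNc1cc(-c2cn(-c3ccccc3)nc2-c2cccc(O)c2)ccn1)Nc1cccc(C(F)(F)F)c1` gives 2780 nM. Among the measured compounds shown here, these two values lie within the scatter of each other, so compound 1 stands level with its only measured neighbour, and neither can be ranked ahead. The unmeasured compound 3 `COc1cccc(-c2nn(-c3ccccc3)cc2-c2ccnc(NCCCNC(=O)Nc3ccc(F)cc3)c2)c1` keeps the rest of compound 1 and makes one change: methyl in place of hydrogen on an oxygen on an aromatic ring, which turns 3-hydroxyphenyl into 3-methoxyphenyl. For the measured compounds named here, the single measured step, a 1.4-fold higher number from compound 1 to compound 2 (0.15 log units; within the scatter), lies on an amide-type nitrogen, not on this oxygen, and it stayed within the scatter. Going by the values given here, no measured pair tests the hydroxy group, so that step is only a weak guide to the size of this one. In this assay, a small move toward a higher number is expected, with nothing firmly predicted beyond the scatter. The expected change is a 1.5-fold higher number from compound 1 to compound 3 (0.18 log units; within the scatter). For compound 3 the estimated value is 3000 nM, within an expected range of 1200 nM to 8000 nM.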

Compound 3, half-maximal inhibitory concentration: 6340 nM
The estimate for compound 3 lay 2.1-fold (0.32 log units) below the measured number, within the range that was stated.
By their numbers in this assay, from the lowest: compounds 1 and 2 (each within the scatter of the next); then compound 3.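

In this assay, the oxygen on the aromatic ring responds to this change: methyl in place of hydrogen there gives a 3.2-fold higher number from compound 1 to compound 3 (0.51 log units; beyond the scatter) and so yields the first difference in the series that clears the scatter, though only a modest one. The earlier step on the amide-type nitrogen, a 1.4-fold higher number from compound 1 to compound 2 (0.15 log units; within the scatter), had shown no separation, so this oxygen is the one place among those shown where a single change moves the number beyond the scatter. Nothing among the data shown explains why replacing this hydrogen raises the number.

The compounds shown leave open whether the rise comes from losing the hydrogen on the oxygen or from adding the methyl, and an amine or a fluorine in place of the hydroxy group, or an ethoxy group with its longer chain, would help to separate those two readings. They also leave open whether 3-methoxyphenyl would raise the number to a similar extent when paired with the 3-(trifluoromethyl)phenyl group of compound 2, since this change is shown on compound 1 alone.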